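The compounds below may be only part of what the source reports. "The series", "measured", "known", "first", "only" and "open" are said of these compounds alone.

In an ADME assay on A549 cells (Homo sapiens) for cytotoxicity, read by MTT assay (on this read-out lower numbers stand for higher toxicity in this test and higher numbers for lower toxicity in this test), compound 2 `CCN(c1ccccc1)S(=O)(=O)c1cc(Cl)ccc1Cl` gives > 5000 nM, which is a limit and not a number. Compound 1 `CCN(c1ccccc1C)S(=O)(=O)c1cc(Cl)ccc1Cl` gives > 25000 nM, also a limit. Compound 3 `CCN(c1ccccc1C#N)S(=O)(=O)c1cc(Cl)ccc1Cl` gives > 5000 nM, again a limit. Compound 4 `CCN(c1ccc(F)cc1)S(=O)(=O)c1cc(Cl)ccc1Cl` differs from compound 2 by fluoro in place of hydrogen on an aromatic carbon, para to a large group: fluoro in place of hydrogen on an aromatic carbon. Going by the values given here, three measured steps bear on this change: a step that the two limits leave unreadable from compound 1 to compound 2, a step that the two limits leave unreadable from compound 1 to compound 3 and a step that the two limits leave unreadable from compound 2 to compound 3. None of them has a readable size. The expectation therefore rests on compound 2 at > 5000 nM, a limit, and no step beyond the scatter is expected in this assay. The estimated step is a step that the limit leaves unreadable from compound 2 to compound 4. Compound 4 is expected at 15000 nM, with an estimated range of 5000 nM to 50000 nM, and may well be reported only as a limit.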

Compound 4, half-maximal cytotoxic concentration: > 5000 nM
Compound 4: a limit, no number; the forecaster's own chance of this, stated with the estimate: 75%; the middle value does not contradict the limit.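

The results for compound 4, compound 2 and compound 1 in this assay are all limits, so neither step to compound 4 can be read. The compounds shown leave open whether fluoro in place of hydrogen changes the read-out at all.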